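The source may report more compounds than this note shows. Statements on the series, on what has been measured and on what is new or still open speak of the compounds shown alone.

Measured so far in a functional assay on MCF7 cells (Homo sapiens) for cytotoxicity, read by neutral red uptake, with a stated time of 3 days; on this read-out higher numbers stand for weaker inhibition and lower numbers for stronger inhibition:
- compound 1 `[N-]=[N+]=Nc1c(F)c(N)c2c(=O)cc(-c3ccc(N)c(F)c3)oc2c1F` gives 460 nM
- compound 2 `CCOC(=O)c1c(F)c(N)c2c(=O)cc(-c3ccc(N)c(F)c3)oc2c1F` gives 1400 nM

Compound 2 stands highest of these two numbers, the weaker inhibition of the pair. Compound 3 `CCC(=O)OCc1c(F)c(N)c2c(=O)cc(-c3ccc(N)c(F)c3)oc2c1F` differs from it by (propanoyloxy)methyl in place of ethoxycarbonyl on an aromatic carbon with (propanoyloxy)methyl in place of ethoxycarbonyl on an aromatic carbon. Among the measured compounds shown here, the one measured step at this place is a 3.0-fold higher number from compound 1 to compound 2 (0.48 log units; beyond the scatter) and it was modest, yet it involved azido, not the entering group. Nothing measured tests (propanoyloxy)methyl, so no shift beyond the scatter is expected in this assay here. The estimated change is a 1.2-fold lower number from compound 2 to compound 3 (0.07 log units; within the scatter) and nothing larger is expected. Compound 3 is estimated at 1200 nM and expected to fall from 400 nM to 3600 nM when measured.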

Compound 3, half-maximal inhibitory concentration: 130 nM
Compound 3: the middle estimate sits 9.2-fold (0.97 log units) above what was measured; the whole stated range lies above it.
By their numbers in this assay, from the lowest: compound 3; then compound 1; then compound 2.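

In this assay, this aromatic carbon proves sensitive to the choice of ester-bearing group: (propanoyloxy)methyl gives an 11-fold lower number from compound 2 to compound 3 (1.03 log units; beyond the scatter), a larger step than any seen before, and a 3.5-fold lower number from compound 1 to compound 3 (0.55 log units; beyond the scatter). The two groups that swap here match in hydrogen-bond donors and acceptors and neither has a ring, so those counts do not separate them. Nothing available explains the step. From the compounds shown here alone, whether the lower number follows the propanoyl part or the methyl link stays open. So does how a hydroxymethyl group, a carboxylic acid or a longer acyl chain would read here.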